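A Third Amide Aryl Group Against an Unreadable Floor

This account rests on a few compounds, and the source may have more. Where it says the series, first, only, none or still open, it means among the compounds named here.

Compound 2 `C/C(=N\OCC(=O)Nc1c(F)cccc1F)C1=C(O)c2ccccc2S(=O)(=O)N1C` was tested in a functional assay on THP-1 cells (Homo sapiens) for inhibition, read by ELISA, with stated times of 2 h and 48 h; a lower number here means a stronger inhibitor, a higher number a weaker inhibitor. In this assay compound 2 gives only a limit, > 20000 nM. Compound 1 `C/C(=N\OCC(=O)Nc1cccc(F)c1)C1=C(O)c2ccccc2S(=O)(=O)N1C` likewise gives only a limit in this assay, > 20000 nM. The step that the two limits leave unreadable from compound 1 to compound 2 is thus unreadable, and both values sit at the limit of > 20000 nM in this assay, at which 2 of the 2 values shown sit. Compound 3 `C/C(=N\OCC(=O)Nc1ccc(Cl)c(C(F)(F)F)c1)C1=C(O)c2ccccc2S(=O)(=O)N1C` differs from compound 2 by 4-chloro-3-(trifluoromethyl)phenyl in place of 2,6-difluorophenyl on an amide-type nitrogen. For the measured compounds named here, no measured step shows a readable change, so the expected step of a number no higher from compound 2 to compound 3 (the limit leaves the size open) carries no direction beyond the scatter. Compound 3 is therefore expected to give about 20000 nM in this assay, in a range from 4000 nM to 100000 nM, most likely again as a limit.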

Compound 3, half-maximal inhibitory concentration: > 20000 nM
Compound 3: no number, only a limit (the forecaster's own chance of this, stated with the estimate: 75%); the middle value lies on the limit itself.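

In this assay compound 3 gives only a limit, > 20000 nM, so the steps linking compound 1, compound 2 and compound 3 cannot be read. The compounds shown leave open whether these three amide aryl groups differ in inhibition at all: the limit of > 20000 nM in this assay, at which 3 of the 3 values shown sit.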